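Dropping the Propanoylamino Group from Compound 1

This account rests on a few compounds, and the source may have more. Where it says the series, first, only, none or still open, it means among the compounds named here.

Compound 1 `CCC(=O)Nc1ccc(OCc2cc3cnc(C#N)nc3n2CCC2CCCCC2)cc1` is a cathepsin S inhibitor; in an assay on isolated protein for inhibition of cathepsin S (Homo sapiens), read by fluorescence (on this read-out lower numbers stand for stronger inhibition and higher numbers for weaker inhibition), compound 1 gives 12 nM. Of the three measured compounds it stands second highest: compound 2 `N#Cc1ncc2cc(COc3ccc(C(N)=O)cc3)n(CCC3CCCCC3)c2n1` gives 2 nM, while compound 3 `CC(C)(C)CCCn1c(Cc2ccc(Cl)cc2)cc2cnc(C#N)nc21` gives 320 nM. Compound 4 `N#Cc1ncc2cc(COc3ccccc3)n(CCC3CCCCC3)c2n1` differs from compound 1 by hydrogen in place of propanoylamino on an aromatic carbon. Among the measured compounds shown here, one measured step bears on this position, a 6.0-fold lower number from compound 1 to compound 2 (0.78 log units; beyond the scatter), but it swaps one group for another rather than removing the group altogether, so it shows only that this position is sensitive. Compound 3 differs in several places and gives no direct guide. A modest weakening is therefore expected, a 3.3-fold higher number from compound 1 to compound 4 (0.52 log units; beyond the scatter). Compound 4 is estimated at 40 nM, within a range from 10 nM to 160 nM.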

Compound 4, half-maximal inhibitory concentration: 10 nM
The estimate for compound 4 lay 4.0-fold (0.60 log units) above the measured number; low and high end bracket the measured number.
By their numbers in this assay, from the lowest: compound 2; then compounds 4 and 1 (each within the scatter of the next); then compound 3.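

Removing the propanoylamino group altogether changes little, with a 1.2-fold lower number from compound 1 to compound 4 (0.08 log units; within the scatter), so inhibition at this level does not depend on that group. Carbamoyl behaves differently: taking it away gives a 5.0-fold higher number from compound 2 to compound 4 (0.70 log units; beyond the scatter), so the stronger inhibition of compound 2 belongs to carbamoyl itself and not simply to having a group at this place. Nothing measured here explains why these two groups differ. From the compounds shown here alone, whether an amine or a carboxylic acid at the same place would match carbamoyl or stay level with hydrogen remains open.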